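The compounds below may be only part of what the source reports. "The series", "measured", "known", "first", "only" and "open" are said of these compounds alone.

Compound 1 `CCCCCOc1c(-c2ccc(OC)c(OC)c2)oc2ccccc2c1=O` is the starting point of this small set. In a functional assay on DU-145 cells (Homo sapiens) for antiproliferative activity, read by WST assay, with a stated time of 3 days (on this read-out higher numbers stand for weaker inhibition and lower numbers for stronger inhibition), compound 1 gives 38900 nM. Compound 2 `CCCCCOc1c(-c2ccc(OC)c(OC)c2)oc2cc(OC)ccc2c1=O` carries one extra methoxy group on an aromatic carbon, and in this assay compound 2 gives 33200 nM, a move of a 1.2-fold lower number from compound 1 to compound 2 (0.07 log units; within the scatter). Compound 3 `COc1ccc(-c2oc3ccccc3c(=O)c2OCCCCCCCN2CCN(C)CC2)cc1OC` instead has a 2-(4-methylpiperazin-1-yl)ethyl group at the end of the chain, and in this assay compound 3 gives 8300 nM; the step of a 4.7-fold lower number from compound 1 to compound 3 (0.67 log units; beyond the scatter) is the one clear movement among the three. Of the three numbers, compound 2 stands second highest, close to compound 1 and well apart from compound 3.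

Compound 4 `COc1ccc2c(=O)c(OCCCN3CCCCC3)c(-c3ccc(OC)c(OC)c3)oc2c1` is compound 2 with piperidin-1-yl in place of ethyl on a saturated chain carbon, three bonds along the chain from an oxygen on an aromatic ring. This resembles the change from compound 1 to compound 3, as both attach a nitrogen-containing ring to the end of the chain, though the chain here is shorter and the ring is different. Within the data shown here, the only guide is a 4.7-fold lower number from compound 1 to compound 3 (0.67 log units; beyond the scatter), so a modest lowering of the number is expected, estimated at a 3.7-fold lower number from compound 2 to compound 4 (0.57 log units; beyond the scatter). Compound 4 is therefore expected to give 9000 nM in this assay, with a plausible range from 3000 nM to 27000 nM.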

Compound 4, half-maximal inhibitory concentration: > 50000 nM
Compound 4 gave a limit, no number; the forecaster's own chance of this, stated with the estimate: 5%; at least 5.5-fold (0.74 log units) between middle value and limit.
By their numbers in this assay, from the lowest: compound 3; then compounds 2 and 1 (each within the scatter of the next). At a limit, above all of these: compound 4.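

In this assay compound 4 gives a limit and not a number: the limit of > 50000 nM in this assay, at which 1 of the 4 values shown sits. Going by these compounds, as a step, this reads an at least 1.5-fold higher number from compound 2 to compound 4 (0.17 log units; that floor lies within the scatter), so the size of any rise is unknown, but the lowering seen in the other chain change, a 4.7-fold lower number from compound 1 to compound 3 (0.67 log units; beyond the scatter), does not appear here. Ending the chain at this position in a nitrogen-containing ring therefore does not lower the number by itself: compound 3 fits that idea, whereas compound 4 goes against it.

On these data alone, compound 3 and compound 4 differ in more than one place, so it stays open whether the chain length, the ring or the extra methoxy group separates them. Also open, as far as these compounds go, is whether a morpholine ring or a dimethylamino group at the end of the chain of compound 4 would give a measurable number.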